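From Urea to Benzamide: Expected Growth Inhibition Shift

This account rests on a few compounds, and the source may have more. Where it says the series, first, only, none or still open, it means among the compounds named here.

Compound 2 `COc1cc(-c2nn(-c3cccc(NC(=O)Nc4ccc(Cl)c(C(F)(F)F)c4)c3)cc2-c2ccncc2)ccc1Cl` gives 1540 nM in a functional assay on COLO 205 cells (Homo sapiens) for inhibition, read by sulforhodamine B assay, with a stated time of 48 h (on this read-out lower numbers stand for stronger inhibition of growth and higher numbers for weaker inhibition of growth), and compound 1 `COc1cc(-c2nn(-c3cccc(NC(=O)Nc4ccc(Cl)c(Cl)c4)c3)cc2-c2ccncc2)ccc1Cl` gives 1720 nM; the two stand within the scatter of each other, as a 1.1-fold lower number from compound 1 to compound 2 (0.05 log units; within the scatter) shows. Compound 3 `COc1cc(-c2nn(-c3cccc(NC(=O)c4ccccc4)c3)cc2-c2ccncc2)ccc1Cl` is not yet measured; the change is phenyl in place of (4-chloro-3-(trifluoromethyl)phenyl)amino on a carbonyl carbon. Within the data shown here, no measured step bears on this carbonyl carbon itself: the only step swaps a group on the ring that now leaves, and it is within the scatter. A loss is nonetheless expected, because removing the whole (4-chloro-3-(trifluoromethyl)phenyl)amino group is a far larger change than the step of a 1.1-fold lower number from compound 1 to compound 2 (0.05 log units; within the scatter). Compound 3 is expected at 6000 nM, with a range of 1800 nM to 25000 nM, a step of a 3.9-fold higher number from compound 2 to compound 3 (0.59 log units; beyond the scatter).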

Compound 3, concentration for total growth inhibition: 3230 nM
The estimate for compound 3 lay 1.9-fold (0.27 log units) above the measured number; the range from low to high includes it.
By their numbers in this assay, from the lowest: compounds 2, 1 and 3 (each within the scatter of the next, the first and the last beyond it).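

On this carbonyl carbon, phenyl in place of (4-chloro-3-(trifluoromethyl)phenyl)amino brings only a modest loss in this assay (a 2.1-fold higher number from compound 2 to compound 3 (0.32 log units; beyond the scatter)). The matching change from the other urea, phenyl in place of (3,4-dichlorophenyl)amino, stays within the scatter (a 1.9-fold higher number from compound 1 to compound 3 (0.27 log units; within the scatter)), so inhibition of growth survives without the amino group and the ring's halogen-bearing substituents. No measurement here explains the size of these steps.

Going by these compounds, the change removes the amino group and those substituents together, so their separate shares remain unknown. Also open, on these data alone, is how a phenyl bearing an amine or a carboxylic acid would behave at this carbon.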